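The source may hold more compounds than are shown below. What is called first, only, known or untested is meant among the compounds shown, and "the series" means these compounds.

Series notes, shared core as in compound 1 `FC(F)(F)c1ccc(CSc2nc(Nc3ccccc3C(F)(F)F)c3ccccc3n2)cc1`. In a functional assay on MDA-MB-231 cells (Homo sapiens) for cytotoxicity, read by MTT assay, with a stated time of 72 h (on this read-out lower numbers stand for stronger inhibition and higher numbers for weaker inhibition), compound 1 gives > 50000 nM, which is a limit of the assay and not a number (the limit of > 50000 nM in this assay, at which 1 of the 3 values shown sits). Compound 2 `Fc1ccc(Nc2nc(SCc3ccc(C(F)(F)F)cc3)nc3ccccc23)cc1` gives 15000 nM in this assay. Compound 3 `O=[N+]([O-])c1ccc(Nc2nc(SCc3ccc(C(F)(F)F)cc3)nc3ccccc23)cc1` gives 8670 nM in this assay. Across these three, an at least 3.3-fold lower number from compound 1 to compound 2 (0.52 log units; beyond the scatter) and an at least 5.7-fold lower number from compound 1 to compound 3 (0.76 log units; beyond the scatter), whereas a 1.7-fold lower number from compound 2 to compound 3 (0.24 log units; within the scatter). Compound 3 therefore holds the lowest of the two numbers recorded, with compound 2 nearest and the gap between them within the scatter, while compound 1 stands only as a limit.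

Compound 4 `COc1ccc(Nc2nc(SCc3ccc(C(F)(F)F)cc3)nc3ccccc23)c(OC)c1` is the next step from compound 3: 2,4-dimethoxyphenyl in place of 4-nitrophenyl on a nitrogen on an aromatic ring. The measured steps that bear on it are the two replacements of the aryl on the ring nitrogen starting from compound 1, an at least 3.3-fold lower number from compound 1 to compound 2 (0.52 log units; beyond the scatter) and an at least 5.7-fold lower number from compound 1 to compound 3 (0.76 log units; beyond the scatter), both at least modest and in the same direction, and the exchange of the substituent on that aryl, a 1.7-fold lower number from compound 2 to compound 3 (0.24 log units; within the scatter), which stayed within the scatter. Going by the values given here, a 2,4-dimethoxyphenyl has no precedent among the three measured compounds, so the direction is open and nothing here points to a step beyond the scatter. This reads as an expected step of a 1.7-fold higher number from compound 3 to compound 4 (0.24 log units; within the scatter). Compound 4 is expected near 15000 nM, in the range 4000 nM to 60000 nM.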

Compound 4, half-maximal inhibitory concentration: > 50000 nM
Compound 4: no number, only a limit; the forecaster's own chance of this, stated with the estimate: 25%; at least 3.3-fold (0.52 log units) between middle value and limit.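

In this assay compound 4 gives > 50000 nM, which is a limit of the assay and not a number: the limit of > 50000 nM in this assay, at which 2 of the 4 values shown sit.

The aryl on this nitrogen on an aromatic ring now shows a change beyond the scatter among the aryls that do not carry 2-(trifluoromethyl)phenyl: an at least 5.7-fold higher number from compound 3 to compound 4 (0.76 log units; beyond the scatter), and an at least 3.3-fold higher number from compound 2 to compound 4 (0.52 log units; beyond the scatter), whereas a 1.7-fold lower number from compound 2 to compound 3 (0.24 log units; within the scatter). The step between compound 1 and compound 4 cannot be read, as both stand as limits; among these four compounds, 4-fluorophenyl and 4-nitrophenyl give numbers while 2-(trifluoromethyl)phenyl and 2,4-dimethoxyphenyl give limits, a split that none of the four goes against but that rests on only two compounds on each side.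

The compounds shown leave open whether the loss in compound 4 goes with one methoxy group or with both, which 4-methoxyphenyl and 2-methoxyphenyl on the same nitrogen would separate. They also leave open how an amine or a carboxylic acid in place of the nitro group of 4-nitrophenyl would read, and what lies behind any of these steps.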